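A few compounds are considered here, and "the series" means these few. Any claim that something is new, unique, unknown or untested is made for them only; others in the source may bear on it.

The series rests on a shared core, seen in compound 1 `CCOc1ccc(-c2cccc(S(=O)(=O)N(C)C)c2)cc1`, which in an assay on COS-7 cells for inhibition of patatin-like phospholipase domain-containing protein 2 (Mus musculus), tested at 200 uM (on this read-out higher numbers stand for more inhibition at the one concentration tested (going by the name of the read-out) and lower numbers for less inhibition), gives 63%. Compound 2 `CCOc1ccc(-c2ccccc2)cc1` gives 35% in this assay, and compound 3 `CCOc1ccc(-c2cccc(C)c2)cc1` gives 54%. Compound 3 therefore stands with compound 1 rather than with compound 2: the step of a number 9 percentage points lower from compound 1 to compound 3 (within the scatter) lies within the scatter, whereas the step of a number 19 percentage points higher from compound 2 to compound 3 (beyond the scatter) lies beyond it.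

Compound 4 `CCCCOC(=O)c1cccc(-c2ccc(OCC)cc2)c1` follows from compound 3 by a single change: butoxycarbonyl in place of methyl on an aromatic carbon. Within the data shown here, two measured steps bear on this. The exchange of dimethylsulfamoyl for methyl in a number 9 percentage points lower from compound 1 to compound 3 (within the scatter) shows that a larger group with acceptors and a methyl give numbers within the scatter of each other at this position, while a number 19 percentage points higher from compound 2 to compound 3 (beyond the scatter) shows that a bare hydrogen there falls clearly behind. A butoxycarbonyl at the same place is thus expected to give no step beyond the scatter, a number 6 percentage points higher from compound 3 to compound 4 (within the scatter). Compound 4 is accordingly estimated at 60% in this assay, within 45% to 75%.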

Compound 4, a percentage reported as inhibition, at one concentration (the size of the read-out at that concentration, not a potency): 61%
Compound 4: the middle estimate sits 1 percentage points below what was measured; the measured number falls inside the stated range.
By their numbers in this assay, from the lowest: compound 2; then compounds 3, 4 and 1 (each within the scatter of the next).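

The butoxycarbonyl group, with its 7 heavy atoms and 2 hydrogen-bond acceptors, stays level with both earlier substituents at this aromatic carbon in this assay: replacing methyl gives a number 7 percentage points higher from compound 3 to compound 4 (within the scatter), and replacing dimethylsulfamoyl gives a number 2 percentage points lower from compound 1 to compound 4 (within the scatter). Its clear separation from the unsubstituted compound, a number 26 percentage points higher from compound 2 to compound 4 (beyond the scatter), adds a third, differently built group to those that stand apart from hydrogen, so across compounds 1, 3 and 4 the choice of substituent does not move the number beyond the scatter. Nothing available explains this result.

As far as these compounds go, it remains open whether an amine or a carboxylic acid at this carbon would stay with these three compounds or fall back towards compound 2. A single concentration also leaves their relative potencies undetermined.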